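A few compounds are considered here, and "the series" means these few. Any claim that something is new, unique, unknown or untested is made for them only; others in the source may bear on it.

Measured compounds:
- compound 1, `O=c1cc(-n2cc(CNc3ccccc3)nn2)c2cc(Br)ccc2o1`: 13200 nM
- compound 2, `O=c1cc(-n2cc(CSc3ccccc3)nn2)c2cc(Br)ccc2o1`: 3510 nM

Among the compounds with values here, in a functional assay on A549 cells (Homo sapiens) for antiproliferative activity, read by MTT assay, with a stated time of 48 h (on this read-out lower numbers stand for stronger inhibition and higher numbers for weaker inhibition), compound 2 gives the lower of the two numbers so far, with compound 1 as its only neighbour at 13200 nM. Within the data shown here, the one measured step, a 3.8-fold lower number from compound 1 to compound 2 (0.58 log units; beyond the scatter), shows that the group on the saturated chain carbon bound to an aromatic carbon matters at a modest scale.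

Compound 3, `O=c1cc(-n2cc(COc3ccc(F)cc3)nn2)c2cc(Br)ccc2o1`, differs from compound 2 as follows: 4-fluorophenoxy in place of phenylsulfanyl on a saturated chain carbon bound to an aromatic carbon. Among the measured compounds shown here, only the step from compound 1 to compound 2 bears on this change, and it concerns a different pair of groups, so its direction cannot simply be carried over. For the measured compounds named here, the single step gives a sense of the size that exchanging this group can produce, but nothing more. Compound 3 is therefore expected to land near compound 2 in this assay, with a step of a 1.4-fold higher number from compound 2 to compound 3 (0.15 log units; within the scatter) that may well stay within the scatter. The estimate for compound 3 in this assay is 5000 nM, with a range from 1500 nM to 16000 nM.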

Compound 3, half-maximal inhibitory concentration: 850 nM
Compound 3: middle estimate off by 5.9-fold (0.77 log units), on the high side; the measured number lies below the stated range.
By their numbers in this assay, from the lowest: compound 3; then compound 2; then compound 1.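

In this assay the group on the saturated chain carbon bound to an aromatic carbon turns out to span a wider range than the first pair showed, since 4-fluorophenoxy in place of phenylsulfanyl gives a 4.1-fold lower number from compound 2 to compound 3 (0.62 log units; beyond the scatter) and the numbers keep falling instead of settling near the earlier low. Measured against the anilino group, the same place gives a 16-fold lower number from compound 1 to compound 3 (1.19 log units; beyond the scatter) and this large step shows that a change at this one place, with the core left as it is, can move the number well beyond the scatter. Nothing among the data given accounts for the order of these three groups.

The exchange from compound 2 to compound 3 alters two things at once, oxygen entering where sulfur leaves and fluorine entering on the ring, so the compounds shown cannot say how much of the step belongs to either one. Plain phenoxy and 4-fluorophenylsulfanyl would separate those two contributions, while whether a chloro or methoxy group on the same phenoxy ring would lower the number further remains open.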